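The source may report more compounds than this note shows. Statements on the series, on what has been measured and on what is new or still open speak of the compounds shown alone.

The measured compounds in this study:

Compound 1, `C=C1C(=O)[C@]23C[C@@]1(O)CC[C@H]2c1ccc(OS(=O)(=O)c2ccc(C)cc2)c(C)c1[C@@H]3Cn1cc(-c2ccc(Br)cc2)nn1`, 1020 nM in a functional assay on HL-60 cells (Homo sapiens) for cytotoxicity, read by MTT assay, with a stated time of 4 days; a lower number here means a stronger inhibitor, a higher number a weaker inhibitor.
Compound 2, `C=C1C(=O)[C@]23C[C@@]1(O)CC[C@H]2c1ccc(OS(=O)(=O)c2ccc(C)cc2)c(C)c1[C@@H]3Cn1cc(-c2ccc(Cl)cc2)nn1`, 1260 nM in this assay.
Compound 3, `C=C1C[C@]23C[C@@]1(O)CC[C@@H]2c1cccc(C)c1[C@@H]3Cn1cc(-c2ccc(Cl)cc2)nn1`, for which this assay gives only a limit, > 20000 nM.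

Compounds 1 and 2 share a core and differ in one place, the change from compound 2 to compound 1 being (bromo in place of chloro on an aromatic carbon). That change gave a 1.2-fold lower number from compound 2 to compound 1 (0.09 log units; within the scatter), so the two values cannot be told apart. Compound 3 carries a different core; the difference between the core of compound 3 and that of compound 2 is not broken down here. The value of compound 3 is a limit of this assay, not a number, and the limit of > 20000 nM in this assay, at which 1 of the 3 values shown sits, describes how the limit is reported.

Compound 4, `C=C1C[C@]23C[C@@]1(O)CC[C@@H]2c1cccc(C)c1[C@@H]3Cn1cc(-c2ccc(Br)cc2)nn1`, has not yet been measured. Going by the values given here, it differs from compound 3 by bromo in place of chloro on an aromatic carbon, the same change in the same place as the one from compound 2 to compound 1. Since that earlier step stayed within the scatter, the same kind of outcome is expected here: compound 4 is estimated to show a step that the limit leaves unreadable from compound 3 to compound 4, because the measured step of a 1.2-fold lower number from compound 2 to compound 1 (0.09 log units; within the scatter) gave no real movement on the other core. Compound 4 is therefore expected to remain near the limit, with an estimated 25000 nM in this assay and a likely range from 10000 nM to 60000 nM.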

Compound 4, half-maximal inhibitory concentration: > 20000 nM
Compound 4: a limit, no number; the forecaster's own chance of this, stated with the estimate: 85%; the middle value lies beyond the limit too.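

In this assay compound 4 gives > 20000 nM, which is a limit and not a number. Compound 3 also sits at a limit, so no step between compound 3 and compound 4 can be read: the limit of > 20000 nM in this assay, at which 2 of the 4 values shown sit.

The compounds shown leave open whether bromo in place of chloro changes the value at all on the core of compound 3.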